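The source may report more compounds than this note shows. Statements on the series, on what has been measured and on what is new or still open speak of the compounds shown alone.

Compound 3 `COc1ccc(-c2cnc3nc(N)nc(N4CCN(Cc5ccccc5)CC4)c3n2)cc1OC` stands second highest of the three measured numbers in a functional assay on cells (T-cell, Homo sapiens) for inhibition; on this read-out higher numbers stand for weaker inhibition and lower numbers for stronger inhibition: compound 3 gives 900 nM. Compound 2 `COc1ccc(-c2cnc3nc(N)nc(N4CCN(c5cc(Cl)cc(Cl)c5)CC4)c3n2)cc1OC` gives 3400 nM, and a 3.8-fold lower number from compound 2 to compound 3 (0.58 log units; beyond the scatter). Compound 1 `COc1ccc(-c2cnc3nc(N)nc(N4CCN(C(=O)NCc5ccccc5)CC4)c3n2)cc1OC` gives 18 nM, the lowest of the three. Compound 4 `COc1ccc(-c2cnc3nc(N)nc(N4CCN(C(=O)NCc5ccc(F)cc5)CC4)c3n2)cc1OC` has not yet been measured. It differs from compound 3 in one place: (4-fluorobenzyl)carbamoyl in place of benzyl on an amine nitrogen in a ring. Among the measured compounds shown here, the step that bears most directly on this is the one between compound 1 and compound 3, where a 50-fold higher number from compound 1 to compound 3 (1.70 log units; beyond the scatter); the change to compound 4 is of the reverse kind, with the carbamoyl group returning and one fluorine added on the ring. In the other step, a 190-fold higher number from compound 1 to compound 2 (2.28 log units; beyond the scatter), the number also rose when the benzylcarbamoyl left. For the measured compounds named here, no measured step involves a fluorine on the ring, so its contribution is unknown from these data. A large step toward stronger inhibition is therefore expected, close to undoing the earlier rise, a 45-fold lower number from compound 3 to compound 4 (1.65 log units; beyond the scatter). Compound 4 is expected to give 20 nM, with a range from 6 nM to 70 nM.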

Compound 4, half-maximal inhibitory concentration: 37 nM
Compound 4: the middle estimate sits 1.9-fold (0.27 log units) below what was measured; measured number inside the range.
By their numbers in this assay, from the lowest: compound 1; then compound 4; then compound 3; then compound 2.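

In this assay, among the compounds shown here, the step of a 2.1-fold higher number from compound 1 to compound 4 (0.31 log units; beyond the scatter) gives the first reading of a fluorine on the aromatic ring of this side group: it raises the number modestly, though beyond the scatter. The gain from the carbamoyl group survives this change, seen in a 24-fold lower number from compound 3 to compound 4 (1.39 log units; beyond the scatter) and a 92-fold lower number from compound 2 to compound 4 (1.96 log units; beyond the scatter), so among the four compounds both carrying a carbamoyl group on this ring nitrogen give lower numbers than both lacking it, and none goes against this. No measurement shown here gives a reason for these steps.

Still open, going by these compounds, is whether a fluorine elsewhere on the ring, or a chlorine or methoxy group in its place, would shift the number similarly. A benzoyl group on the ring nitrogen would test whether the amide nitrogen and its hydrogen are needed or the carbonyl alone suffices.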